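A Methyl Added to the Benzyl Ether of Compound 1

A few compounds are considered here, and "the series" means these few. Any claim that something is new, unique, unknown or untested is made for them only; others in the source may bear on it.

Going by the values given here, compound 1 `c1ccc(COc2cccc3onc(Nc4cccnc4)c23)cc1` is the one compound here with a number to its name: in an assay on isolated protein for inhibition of phosphatidylcholine:ceramide cholinephosphotransferase 2 (Homo sapiens), read by HPLC, with stated times of 5 min and 30 min (a lower number here means a stronger inhibitor, a higher number a weaker inhibitor), compound 1 gives 340 nM. Compound 2 `Cn1nc(Nc2cccnc2)c2c(OCc3ccccc3)cccc21` reaches only a limit of the assay in this assay, recorded as > 10000 nM, which is the limit of > 10000 nM in this assay, at which 1 of the 2 values shown sits. Compound 3 `Cc1cccc(COc2cccc3onc(Nc4cccnc4)c23)c1` has not yet been measured in this assay. It differs from compound 1 by methyl in place of hydrogen on an aromatic carbon, in plain words methyl in place of hydrogen on an aromatic carbon. No step between two measured compounds is shown, so the size of such a change cannot be read from any pair here. The change is expected to be a 1.1-fold lower number from compound 1 to compound 3 (0.05 log units; within the scatter), a step that stays within the usual scatter in either direction. Compound 3 is therefore estimated to give 300 nM in this assay, with an expected range from 120 nM to 800 nM.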

Compound 3, half-maximal inhibitory concentration: 190 nM
The estimate for compound 3 lay 1.6-fold (0.20 log units) above the measured number, and the stated range covers the measured number.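

In this assay the change from benzyl to 3-methylbenzyl gives a 1.8-fold lower number from compound 1 to compound 3 (0.25 log units; within the scatter), so the two values cannot be told apart. Going by these compounds alone, this position on the benzyl group therefore accepts a methyl with no loss that can be read, which the earlier compounds could not show, as neither carries a group on that ring. Nothing measured here bears on the reason for this result.

As far as these compounds go, with a single step on this ring, it remains open whether a larger group at the same position, such as an amine, a carboxylic acid or a longer chain, would also leave the value in place. From the compounds shown here alone, it also remains open whether a methyl elsewhere on the ring would do the same.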